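Swapping the hydroxyphenyl of compound 3 for a pyridine

A few compounds are considered here, and "the series" means these few. Any claim that something is new, unique, unknown or untested is made for them only; others in the source may bear on it.

The series shares one core, varied only at the aryl group on the double-bonded chain carbon. Within the data shown here, in a functional assay on SW-620 cells (Homo sapiens) for cytotoxicity, read by MTT assay, with a stated time of 72 h (on this read-out higher numbers stand for weaker inhibition and lower numbers for stronger inhibition), compound 1 `COc1ccc(/C=C2\S/C(=N\c3csc(-c4ccc(Cl)cc4)c3)NC2=O)cc1` gives 28100 nM, while compound 2 `CN(C)c1ccc(/C=C2\S/C(=N\c3csc(-c4ccc(Cl)cc4)c3)NC2=O)cc1` gives 800 nM; the single step recorded, a 35-fold lower number from compound 1 to compound 2 (1.55 log units; beyond the scatter), is large. Compound 3 `O=C1N/C(=N/c2csc(-c3ccc(Cl)cc3)c2)S/C1=C\c1ccc(O)cc1` carries a hydroxyl at the same ring position, but in this assay compound 3 gives "not determined" (no result reported), so it cannot be placed among these numbers.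

Compound 4 `O=C1N/C(=N/c2csc(-c3ccc(Cl)cc3)c2)S/C1=C\c1ccccn1` differs from compound 3 by pyridin-2-yl in place of 4-hydroxyphenyl on a double-bonded chain carbon bound to a double-bonded ring carbon. Among the measured compounds shown here, no measured step matches this change: the step from compound 1 to compound 2 alters a substituent on the ring rather than replacing the ring itself, so it bears on the present change only by showing that this position can move the read-out widely. With compound 3 itself unmeasured, neither direction nor size of the step can be drawn from the data, and the expectation must rest on the spread between compound 1 and compound 2.

Compound 4 is therefore expected to fall at about 15000 nM in this assay, with a range from 2000 nM to 80000 nM.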

Compound 4, half-maximal inhibitory concentration: > 50000 nM
Compound 4 ended at the assay's limit; the forecaster's own chance of this, stated with the estimate: 25%; middle value at least 3.3-fold (0.52 log units) from the limit.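

In this assay, exchanging the whole aryl ring on the double-bonded chain carbon, rather than only a substituent on it, also moves the read-out widely: pyridin-2-yl in place of 4-(dimethylamino)phenyl gives an at least 62-fold higher number from compound 2 to compound 4 (1.79 log units; beyond the scatter). This is the second large step at this position, so the low number of compound 2 is lost when the 4-(dimethylamino)phenyl gives way to this ring. Against 4-methoxyphenyl, the same kind of exchange gives an at least 1.7-fold higher number from compound 1 to compound 4 (0.25 log units; that floor lies within the scatter), so the values shown do not separate pyridin-2-yl from that group, and compound 4 is known here only through a limit of the assay: the limit of > 50000 nM in this assay, at which 1 of the 4 values shown sits.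

Going by these compounds, the step between compound 3 and compound 4 cannot be read, so the place of pyridin-2-yl relative to 4-hydroxyphenyl stays open. Also open, on these data alone, is whether the low number of compound 2 belongs to dimethylamino alone or would persist with another amine, such as a morpholine or a primary amine, on the phenyl ring, and whether a dimethylamino group on the pyridine ring would bring it back.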